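The source may report more compounds than this note shows. Statements on the series, on what has been measured and on what is new or still open speak of the compounds shown alone.

Among the measured compounds shown here, compound 2 `CN(C)CCCNc1nc(N(C)C)nc2cc(-c3ccc(C(F)(F)F)cc3)sc12` gives the higher of the two numbers so far in a physicochemical assay for solubility, in phosphate buffer, at pH 6.5; on this read-out higher numbers stand for higher solubility and lower numbers for lower solubility: in this assay compound 2 gives 168 ug/mL, whereas compound 1 `CNc1nc(N)c2sc(-c3ccc(C(F)(F)F)cc3)cc2n1` gives 3.1 ug/mL, a gap beyond the scatter. Compound 3 `CN(C)CCCNc1nc(NCc2ccccc2)nc2cc(-c3ccc(C(F)(F)F)cc3)sc12` differs from compound 2 by benzylamino in place of dimethylamino on an aromatic carbon, the site lying between two ring nitrogen atoms. For the measured compounds named here, no measured step of this kind exists in the set. Compound 3 is expected to fall below compound 2 by a step of a 5.6-fold lower number from compound 2 to compound 3 (0.75 log units; beyond the scatter), beyond the scatter. The estimate for compound 3 in this assay is 30 ug/mL, within a range of 8 ug/mL to 100 ug/mL.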

Compound 3, solubility: < 5 ug/mL
Compound 3: no number, only a limit; the forecaster's own chance of this, stated with the estimate: 5%; at least 6.0-fold (0.77 log units) between middle value and limit.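

Position between two ring nitrogen atoms: with the (3-(dimethylamino)propyl)amino group held constant, the group at this site alone moves the read-out in this assay, giving an at least 33-fold lower number from compound 2 to compound 3 (1.52 log units; beyond the scatter). For compound 3 this is a limit and not a number, so the full size of the step remains unknown: the limit of < 5 ug/mL in this assay, at which 1 of the 3 values shown sits.

Open: whether the drop follows the added six-membered aromatic ring, the added hydrogen-bond donor or both. A benzyl(methyl)amino group at this site, which keeps the aromatic ring without that donor, would separate the two.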